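A Trifluoromethyl in Place of Isopropyl at the Hydroxyl Carbon

A few compounds are considered here, and "the series" means these few. Any claim that something is new, unique, unknown or untested is made for them only; others in the source may bear on it.

Three analogues sharing one core have been measured in an assay on isolated protein for inhibition of protein kinase C epsilon type (Homo sapiens), read by coupled enzyme assay; on this read-out higher numbers stand for weaker inhibition and lower numbers for stronger inhibition. Compound 1 `C[C@H](O)Cc1cc(-c2ccnc3[nH]nc(C(F)(F)F)c23)cc(C2(C#N)CC2)c1` gives 51 nM, compound 2 `CCC(O)Cc1cc(-c2ccnc3[nH]nc(C(F)(F)F)c23)cc(C2(C#N)CC2)c1` gives 49 nM, and compound 3 `CC(C)C(O)Cc1cc(-c2ccnc3[nH]nc(C(F)(F)F)c23)cc(C2(C#N)CC2)c1` gives 215 nM, the highest of the three numbers. The step of a 4.2-fold higher number from compound 1 to compound 3 (0.62 log units; beyond the scatter) and the step of a 4.4-fold higher number from compound 2 to compound 3 (0.64 log units; beyond the scatter) both went upward, while a 1.0-fold lower number from compound 1 to compound 2 (0.02 log units; within the scatter) did not move beyond the scatter. Compound 4 `N#CC1(c2cc(CC(O)C(F)(F)F)cc(-c3ccnc4[nH]nc(C(F)(F)F)c34)c2)CC1` carries trifluoromethyl in place of isopropyl on a saturated chain carbon bound to an oxygen on a saturated carbon and a saturated chain carbon. Among the compounds with values here, no measured step involves a trifluoromethyl at a saturated chain carbon bound to an oxygen on a saturated carbon and a saturated chain carbon, so the two upward steps into compound 3 are the only guide. Compound 4 is therefore expected to give 100 nM, between 35 nM and 300 nM, a step of a 2.2-fold lower number from compound 3 to compound 4 (0.33 log units; beyond the scatter) that is expected to fall modestly.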

Compound 4, inhibition constant: 267 nM
The estimate for compound 4 lay 2.7-fold (0.43 log units) below the measured number; the measured number falls inside the stated range.
By their numbers in this assay, from the lowest: compounds 2 and 1 (each within the scatter of the next); then compounds 3 and 4 (each within the scatter of the next).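

Trifluoromethyl in place of isopropyl on this saturated chain carbon bound to an oxygen on a saturated carbon and a saturated chain carbon leaves the two compounds indistinguishable (a 1.2-fold higher number from compound 3 to compound 4 (0.09 log units; within the scatter)). Trifluoromethyl in place of ethyl (a 5.4-fold higher number from compound 2 to compound 4 (0.74 log units; beyond the scatter)) and 2,2,2-trifluoro-1-hydroxyethyl in place of 1-hydroxyethyl (a 5.2-fold higher number from compound 1 to compound 4 (0.72 log units; beyond the scatter)) both lead upward beyond the scatter. The higher number at this position is therefore not confined to isopropyl.

As far as these compounds go, whether an amine, a carboxylic acid or a longer chain at this carbon would keep the higher number remains open. Nothing available explains why trifluoromethyl and isopropyl give matching results here.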